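Methyl on the amine nitrogen: compound 2 to compound 3

The source may report more compounds than this note shows. Statements on the series, on what has been measured and on what is new or still open speak of the compounds shown alone.

Measured so far:
compound 1, `COc1cccc(OC)c1[C@@H]1C[C@H](N(C)C)C(=O)N1Cc1ccc(OC(F)(F)F)cc1`: 8720 nM in a functional assay on CHO cells for antagonist activity at Orexin/Hypocretin receptor type 1 (Homo sapiens), read by FLIPR and calcium flux; on this read-out higher numbers stand for weaker inhibition and lower numbers for stronger inhibition
compound 2, `CN[C@@H]1C[C@@H](c2c(OC)cccc2OC)N(Cc2ccc(OC(F)(F)F)cc2)C1=O`: 2400 nM in this assay

Compound 2 holds the lower of the two numbers; the number for compound 1 lies higher, and the gap between them is beyond the usual scatter. Compound 3, `COc1cccc(OC)c1[C@@H]1C[C@@H](N(C)C)C(=O)N1Cc1ccc(OC(F)(F)F)cc1`, is not yet measured and differs from compound 2 by methyl in place of hydrogen on an amine nitrogen. Among the measured compounds shown here, no measured pair shows this change, so the expected step from compound 2 to compound 3 is small, at most a modest move toward a higher number, and may well stay within the scatter. Compound 3 is therefore expected to give 3500 nM in this assay, with a range of 1200 nM to 10000 nM, which corresponds to an estimated step of a 1.5-fold higher number from compound 2 to compound 3 (0.16 log units; within the scatter).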

Compound 3, half-maximal inhibitory concentration: 3620 nM
For compound 3 the middle estimate is 1.0-fold (0.01 log units) below the measured one, and the stated range covers the measured number.
By their numbers in this assay, from the lowest: compounds 2 and 3 (each within the scatter of the next); then compound 1.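

In this assay, methylamino to dimethylamino gives a 1.5-fold higher number from compound 2 to compound 3 (0.18 log units; within the scatter), so this amine nitrogen carries either group without a readable difference. Configuration, by contrast, does separate two compounds, with a 2.4-fold lower number from compound 1 to compound 3 (0.38 log units; beyond the scatter). That gap rests on the stereocentre at a saturated ring carbon alone: the fact that compounds 1 and 3 differ only in the configuration as drawn

Open questions are whether a primary amine or a longer chain such as ethyl on this nitrogen stays at the same level, and whether the configuration step also holds for the methylamino group.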